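The source may report more compounds than this note shows. Statements on the series, on what has been measured and on what is new or still open speak of the compounds shown alone.

Measured so far in a toxicity assay on THP-1 cells (Homo sapiens) for inhibition; a lower number here means that less compound is tolerated, a higher number that more compound is tolerated:
- Compound 1 `COc1ccc(-c2cnc(NC(=O)c3ccc(F)cc3)[nH]2)cc1`: > 100000 nM (a limit)
- Compound 2 `CCCCn1c(-c2ccc(OC)cc2)cnc1NC(=O)c1ccc(F)cc1`: > 100000 nM (a limit)

Compound 2 has no numerical value, only the limit > 100000 nM. Compound 1 is also known only through a limit, > 100000 nM. Both measurements therefore sit together: the limit of > 100000 nM in this assay, at which 2 of the 2 values shown sit. Among the measured compounds shown here, the one measured step, butyl in place of hydrogen on an aromatic nitrogen, is a step that the two limits leave unreadable from compound 1 to compound 2.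

Compound 3 `COc1ccc(-c2cnc(NC(=O)c3ccc(F)cc3)n2C(C)C)cc1` has isopropyl in place of butyl on an aromatic nitrogen. The change stays at the same place on the shared core, on the aromatic nitrogen next to the ring atom that bears a 4-methoxyphenyl group. For the measured compounds named here, the only step bearing on it gives no size, so it offers no direction. No readable step is expected in this assay, and compound 3 will most likely be reported again only as a limit. The expected change is a step that the limit leaves unreadable from compound 2 to compound 3. For compound 3 the estimated value is 120000 nM. The expected range for compound 3 runs from 60000 nM to 300000 nM.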

Compound 3, half-maximal cytotoxic concentration: > 50000 nM
Compound 3: a limit, no number (the forecaster's own chance of this, stated with the estimate: 85%); the middle value does not contradict the limit.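

In this assay compound 3 gives > 50000 nM, which is a limit and not a number. Among the compounds shown here, compound 1 and compound 2 are also known only through limits, so no step among the three compounds can be read. The compounds shown leave open whether hydrogen, butyl and isopropyl on the aromatic nitrogen differ at all in this assay.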